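The compounds below may be only part of what the source reports. "The series", "measured", "known", "first", "only" and "open" are said of these compounds alone.

Measured compounds:
compound 1, `COc1ccc2[nH]c(C(=O)N3CC(=O)N(Cc4ccccc4)[C@@H](COc4ccccc4)C3)cc2c1`, gives 12200 nM in a physicochemical assay for solubility, read by spectrophotometry, in phosphate buffer, with a stated time of 2 h, at pH 7.4; a lower number here means a less soluble compound, a higher number a more soluble compound
compound 2, `COc1cccc(CN2C(=O)CN(C(=O)c3cc4cc(OC)ccc4[nH]3)C[C@@H]2CCc2ccccc2)c1`, gives 5100 nM in this assay
compound 3, `COc1cccc(CN2C(=O)CN(C(=O)c3cc4cc(OC)ccc4[nH]3)C[C@@H]2CC2CCCCC2)c1`, gives 21400 nM in this assay

Among these three numbers compound 1 stands second highest. Compound 3 sits above it, but the gap between them is within the scatter, so the two cannot be told apart. Compound 2 sits lower, and that gap is beyond the scatter.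

The unmeasured compound 4, `COc1ccc2[nH]c(C(=O)N3CC(=O)N(Cc4ccccc4)[C@@H](CN4[C@H](C)COC[C@@H]4C)C3)cc2c1`, comes from compound 1 by one change: 3,5-dimethylmorpholin-4-yl in place of phenoxy on a saturated chain carbon bound to a saturated ring carbon.

For the measured compounds named here, only one measured step exists here, a 4.2-fold higher number from compound 2 to compound 3 (0.62 log units; beyond the scatter), and it swaps a cyclohexyl for a benzyl on a different part of the shared core, so it says nothing direct about a phenoxy giving way to a 3,5-dimethylmorpholin-4-yl. Going by the values given here, no measured pair covers that exchange. The estimate therefore rests on the value of compound 1 alone, with a wide range to reflect the lack of a guiding step, and compound 4 is expected to land near it, with a 1.6-fold higher number from compound 1 to compound 4 (0.21 log units; within the scatter) as the expected step. For compound 4 the estimated solubility is 20000 nM, between 6000 nM and 70000 nM.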

Compound 4, solubility: > 100000 nM
Compound 4: a limit, no number; the forecaster's own chance of this, stated with the estimate: 5%; middle value at least 5.0-fold (0.69 log units) away from the limit.
By their numbers in this assay, from the lowest: compound 2; then compounds 1 and 3 (each within the scatter of the next). At a limit, above all of these: compound 4.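

At the position on a saturated chain carbon bound to a saturated ring carbon, the exchange of phenoxy for 3,5-dimethylmorpholin-4-yl now has a measured step of its own: an at least 8.1-fold higher number from compound 1 to compound 4 (0.91 log units; beyond the scatter). In this assay, from the compounds shown here alone, compound 4 gives > 100000 nM, which is a limit of the assay and not a number, so the full size of the step stays unknown. The exchange removes a six-membered aromatic ring of carbon only and brings in a six-membered non-aromatic ring with 2 hetero atoms, and at this position it moves the number beyond the scatter.

Going by these compounds, whether a plain morpholin-4-yl or a piperidin-1-yl at this place would give a similar step stays open, so the shares of the ring nitrogen, the ring oxygen and the two methyl groups cannot be separated. Also open, on these data alone, is whether another stereochemical arrangement of those two methyl groups would behave the same way.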